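Swapping the aryl group on a tetrazole-based enzyme inhibitor

A few compounds are considered here, and "the series" means these few. Any claim that something is new, unique, unknown or untested is made for them only; others in the source may bear on it.

Compound 1 `CCCCCCCCc1ccc(OCC(=O)Cn2nnc(-c3ccccc3)n2)cc1`: 24 nM
Compound 2 `CCCCCCCCc1ccc(OCC(=O)Cn2nnc(-c3ccccc3Cl)n2)cc1`: 32 nM

In an assay on microsomes from brain for inhibition of Fatty-acid amide hydrolase 1 (Rattus norvegicus), read by fluorescence and HPLC, with a stated time of 60 min (a lower number here means a stronger inhibitor, a higher number a weaker inhibitor), compound 1 gives 24 nM, and compound 2 gives 32 nM. Among the compounds with values here, compound 2 has the higher of the two numbers, yet the one step measured, a 1.3-fold higher number from compound 1 to compound 2 (0.12 log units; within the scatter), stays within the scatter. Compound 3 `CCCCCCCCc1ccc(OCC(=O)Cn2nnc(-c3cccc(S(=O)(=O)N(C)C)c3)n2)cc1` carries a larger change: 3-(dimethylsulfamoyl)phenyl in place of 2-chlorophenyl on an aromatic carbon. Within the data shown here, no measured step covers a group of this kind, so the only guide is that the small change from compound 1 to compound 2 barely moved the number. The estimate for compound 3 is 50 nM, in the range 12 nM to 200 nM, which means an expected step of a 1.6-fold higher number from compound 2 to compound 3 (0.19 log units; within the scatter) in this assay.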

Compound 3, half-maximal inhibitory concentration: 420 nM
Compound 3: middle estimate off by 8.4-fold (0.92 log units), on the low side; the whole stated range lies below it.
By their numbers in this assay, from the lowest: compounds 1 and 2 (each within the scatter of the next); then compound 3.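

In this assay the aryl group proves less forgiving than compounds 1 and 2 suggested. Chloro left the number within the scatter, but the dimethylsulfamoyl group gives a 13-fold higher number from compound 2 to compound 3 (1.12 log units; beyond the scatter) and an 18-fold higher number from compound 1 to compound 3 (1.24 log units; beyond the scatter) as well, both large steps. Nothing measured here says why the number rose. Still open, going by these compounds, is whether a smaller group on the phenyl ring, such as methoxy or an amine, would keep the number close to that of compound 1. Also open, on these data alone, is whether the dimethylsulfamoyl group itself or its place on the ring sets the size of the step.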